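Replacing an Alkyl Ether with Fluorophenyl in Compound 2

The source may hold more compounds than are shown below. What is called first, only, known or untested is meant among the compounds shown, and "the series" means these compounds.

Measured compounds:
compound 1 `COC(C)(C)[C@@H](O)C(=O)N1[C@H](C(=O)NCc2cc(Cl)ccc2-n2cnnn2)C[C@@H]2C[C@@H]21`: 16 10^-6 cm/s
compound 2 `COC(C)(C)[C@@H](O)C(=O)N1N=CC[C@H]1C(=O)NCc1cc(Cl)ccc1-n1cnnn1`: 1.7 10^-6 cm/s
compound 3 `O=C(O[C@@H](C(=O)N1N=CC[C@H]1C(=O)NCc1cc(Cl)ccc1-n1cnnn1)c1ccc(F)cc1)c1ccccc1`: 43 10^-6 cm/s

In an ADME assay on Caco-2 cells (Homo sapiens) for permeability, read by LC-MS, in the apical to basolateral direction, with a stated time of 60 min, at pH 6.5 (a lower number here means that the compound crosses the layer more slowly, a higher number that the compound crosses the layer faster), compound 2 gives 1.7 10^-6 cm/s, the lowest of the three numbers. Compound 1 gives 16 10^-6 cm/s and compound 3 gives 43 10^-6 cm/s, both higher than compound 2 by more than the usual scatter. Compound 4 `O=C(NCc1cc(Cl)ccc1-n1cnnn1)[C@@H]1CC=NN1C(=O)[C@H](O)c1ccccc1F` is not yet measured. It differs from compound 2 in one place: 2-fluorophenyl in place of 1-methoxy-1-methylethyl on a saturated chain carbon bound to a carbonyl carbon and an oxygen on a saturated carbon. Among the compounds with values here, no measured pair shows this exact change, so the expectation rests on the three values alone, chiefly on compound 3 giving 43 10^-6 cm/s with an aromatic ring at the corresponding carbon. The step from compound 2 to compound 4 is expected to be upward and beyond the scatter, a 4.7-fold higher number from compound 2 to compound 4 (0.67 log units; beyond the scatter). Compound 4 is therefore estimated at 8 10^-6 cm/s, within a range of 3 10^-6 cm/s to 25 10^-6 cm/s.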

Compound 4, apparent permeability: 8.9 10^-6 cm/s
For compound 4 the middle estimate is 1.1-fold (0.05 log units) below the measured one; measured number inside the range.
By their numbers in this assay, from the lowest: compound 2; then compounds 4 and 1 (each within the scatter of the next); then compound 3.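

This is the first pair among the compounds shown that differs in one place, so it shows directly that the group on this saturated chain carbon matters: in this assay, 2-fluorophenyl in place of 1-methoxy-1-methylethyl gives a 5.2-fold higher number from compound 2 to compound 4 (0.72 log units; beyond the scatter). The change swaps a group with 1 hydrogen-bond acceptor for an aromatic ring with 0, but this single pair cannot separate those features from each other. No measurement here explains the rise. Going by these compounds, what remains open is how unsubstituted phenyl, an amine or a longer alkyl chain would read at this carbon.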